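This account rests on a few compounds, and the source may have more. Where it says the series, first, only, none or still open, it means among the compounds named here.

Of the compounds shown here, two on the shared core have been tested in a functional assay on K562 cells (Homo sapiens), read by MTT assay, with a stated time of 72 h; a higher number here means a weaker inhibitor, a lower number a stronger inhibitor: compound 1 `COc1nc(N)nc2c1c(-c1cccs1)cn2[C@@H]1O[C@H](CO)[C@@H](O)[C@H]1O` and compound 2 `COc1nc(N)nc2c1c(-c1cc3ccccc3o1)cn2[C@@H]1O[C@H](CO)[C@@H](O)[C@H]1O`. Compound 1 gives only a limit, > 20000 nM, and not a number. Among the measured compounds shown here, compound 2 gives 14600 nM, the only true number so far, so its standing rests on a single comparison with compound 1. The next compound, compound 3 `C#Cc1cn([C@@H]2O[C@H](CO)[C@@H](O)[C@H]2O)c2nc(N)nc(OC)c12`, differs from compound 2 at one place: ethynyl in place of 1-benzofuran-2-yl on an aromatic carbon. In words, this is ethynyl in place of 1-benzofuran-2-yl on an aromatic carbon. For the measured compounds named here, the only measured step that bears on this position is an at least 1.3-fold lower number from compound 1 to compound 2 (0.13 log units; that floor lies within the scatter). That step exchanged one aromatic group for another and did not clear the scatter. Going by the values given here, it gives no direction for the removal of the aromatic rings, and no measured step covers a change of this kind. No shift beyond the scatter in this assay is therefore expected, though the uncertainty is wide and a limit may again be reported. The expected change is a 1.5-fold lower number from compound 2 to compound 3 (0.16 log units; within the scatter). The estimate for compound 3 is 10000 nM, with an expected range from 1500 nM to 40000 nM.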

Compound 3, half-maximal inhibitory concentration: > 20000 nM
Compound 3 ended at the assay's limit (the forecaster's own chance of this, stated with the estimate: 35%); middle value at least 2.0-fold (0.30 log units) from the limit.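

In this assay, replacing 1-benzofuran-2-yl with ethynyl on this aromatic carbon gives an at least 1.3-fold higher number from compound 2 to compound 3 (0.13 log units; that floor lies within the scatter), so this change cannot be said to weaken the compound, although the true size of the step may be larger than that floor. Among the compounds shown here, the earlier compounds had exchanged only one aromatic group for another, whereas this result shows that a group with no ring at this position also gives no true number, only a limit. The step between compound 1 and compound 3 cannot be read, and the result leaves compound 2 as the only compound with a true number, while the other two sit at the same limit: the limit of > 20000 nM in this assay, at which 2 of the 3 values shown sit.

From the compounds shown here alone, how far compound 1 and compound 3 lie beyond that limit remains open, so thiophen-2-yl and ethynyl cannot be ranked against each other, and it is unclear whether the step from compound 2 to compound 3 is a real one. Also open, going by these compounds, is whether an amine, a carboxylic acid or a longer carbon chain on this aromatic carbon would give a true number in this assay.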